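Same Isopropyl Change on a Second Core: What to Expect

The source may report more compounds than this note shows. Statements on the series, on what has been measured and on what is new or still open speak of the compounds shown alone.

Compound 1 `CCOC(=O)c1noc2c1CN(C(=O)c1ccc(O)cc1O)CC2` was tested in a functional assay on NCI-H460 cells (Homo sapiens) for inhibition, read by sulforhodamine B assay, with a stated time of 72 h; on this read-out higher numbers stand for weaker inhibition and lower numbers for stronger inhibition. In this assay compound 1 gives > 20000 nM, which is a limit of the assay and not a number. Compound 2 `CCOC(=O)c1noc2c1CN(C(=O)c1cc(C(C)C)c(O)cc1O)CC2` carries isopropyl in place of hydrogen on an aromatic carbon and in this assay gives 870 nM; the step of an at least 22-fold lower number from compound 1 to compound 2 (1.36 log units; beyond the scatter) is large. Compound 3 `CCNC(=O)c1noc2c1CN(C(=O)c1ccc(O)cc1O)CC2` differs from compound 1 by ethylamino in place of ethoxy on a carbonyl carbon. In this assay compound 3 gives > 20000 nM, again a limit and not a number. Hence a step that the two limits leave unreadable from compound 1 to compound 3 cannot be sized, and the limit of > 20000 nM in this assay, at which 2 of the 3 values shown sit, marks where both sit. Compound 4 `CCNC(=O)c1noc2c1CN(C(=O)c1cc(C(C)C)c(O)cc1O)CC2` is not yet measured and carries isopropyl in place of hydrogen on an aromatic carbon, the same change in the same place as before. Because the earlier step of an at least 22-fold lower number from compound 1 to compound 2 (1.36 log units; beyond the scatter) was large, compound 4 is expected near 1500 nM, between 400 nM and 20000 nM. The expected step of an at least 13-fold lower number from compound 3 to compound 4 (1.12 log units; beyond the scatter) stays uncertain, as compound 3 shows only a limit.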

Compound 4, half-maximal inhibitory concentration: 450 nM
Estimate against measurement, compound 4: 3.3-fold (0.52 log units) above; the measured number falls inside the stated range.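

In this assay, isopropyl in place of hydrogen on an aromatic carbon carries over to the second core and again gives a large step, an at least 44-fold lower number from compound 3 to compound 4 (1.64 log units; beyond the scatter). The sizes on the two cores cannot be compared, and the step between the two compounds without isopropyl cannot be read, as each of them gives only a limit of the assay and not a number: the same change on two cores in this assay, an at least 22-fold lower number (1.36 log units; beyond the scatter) from compound 1 to compound 2 and an at least 44-fold lower number (1.64 log units; beyond the scatter) from compound 3 to compound 4; the limit leaves it open whether they differ With isopropyl present, ethylamino in place of ethoxy gives a 1.9-fold lower number from compound 2 to compound 4 (0.29 log units; within the scatter), so this pair shows no real difference.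

Two cores do not show that the change would carry to any other core. Still open, from the compounds shown here alone, is how a longer chain or an amine would fare on that aromatic carbon, or a carboxylic acid in place of ethoxy.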